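The compounds below may be only part of what the source reports. "The series", "measured", "known", "first", "only" and "open" are said of these compounds alone.

Of the compounds shown here, three sharing one core have been measured in an in vivo functional assay on the whole organism for inhibition, with Rattus norvegicus as the target; a higher number here means that more compound is needed for the effect, a lower number that less compound is needed. Compound 1 `CCCCc1nc(C)c(CCC(=O)OCC)c(=O)n1Cc1ccc(-c2ccccc2-c2nnn[nH]2)cc1` gives 0.066 mg/kg. Compound 2 `CCCCc1nc(C)c(CC(=O)N2CCSCC2)c(=O)n1Cc1ccc(-c2ccccc2-c2nnn[nH]2)cc1` gives 0.038 mg/kg, and the two values lie close together, as the step of a 1.7-fold lower number from compound 1 to compound 2 (0.24 log units; within the scatter) shows. Compound 3 `CCCCc1nc(C)c(CCC(=O)N2CCSCC2)c(=O)n1Cc1ccc(-c2ccccc2-c2nnn[nH]2)cc1` gives 0.204 mg/kg, the highest number of the three, so more of it is needed for the effect than of either of the others.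

Compound 4 `CCCCc1nc(C)c(CCC(=O)N2CCCCC2)c(=O)n1Cc1ccc(-c2ccccc2-c2nnn[nH]2)cc1` changes compound 3 at a single place, on a carbonyl carbon whose other neighbour is a saturated chain carbon: piperidin-1-yl in place of thiomorpholin-4-yl on a carbonyl carbon. In words, piperidin-1-yl stands in place of thiomorpholin-4-yl, so one six-membered non-aromatic ring replaces another. Among the compounds with values here, no measured pair makes this exact exchange. The nearest evidence is the step of a 3.1-fold higher number from compound 1 to compound 3 (0.49 log units; beyond the scatter), which is modest and swaps ethoxy for thiomorpholin-4-yl on that same carbonyl carbon. The step of a 5.4-fold higher number from compound 2 to compound 3 (0.73 log units; beyond the scatter) is also modest, but it alters the chain and leaves the ring untouched, so it bears on this exchange less directly. Neither step is large, and the exchange of one ring for a closely similar ring looks smaller than the swap from ethoxy. The expected step is therefore a 1.2-fold lower number from compound 3 to compound 4 (0.08 log units; within the scatter), which would stay within the scatter. The estimate for compound 4 is 0.17 mg/kg, with an expected range from 0.06 mg/kg to 0.5 mg/kg.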

Compound 4, dose for half-maximal effect: 0.164 mg/kg
Beside the measured number, compound 4's estimate is 1.0-fold (0.02 log units) above it, and the stated range covers the measured number.
By their numbers in this assay, from the lowest: compounds 2 and 1 (each within the scatter of the next); then compounds 4 and 3 (each within the scatter of the next).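

In this assay, within the data shown here, the step of a 1.2-fold lower number from compound 3 to compound 4 (0.09 log units; within the scatter) gives the first direct reading of one ring exchanged for another on this carbonyl carbon: removing the ring sulfur, with piperidin-1-yl in place of thiomorpholin-4-yl, produces no change beyond the usual scatter. The other two comparisons remain beyond the scatter, as the matching steps to compound 3 did: a 2.5-fold higher number from compound 1 to compound 4 (0.40 log units; beyond the scatter) exchanges ethoxy for piperidin-1-yl, while a 4.3-fold higher number from compound 2 to compound 4 (0.64 log units; beyond the scatter) changes both the ring and the chain, so it cannot be credited to either alone. Nothing available explains why these two rings read alike.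

The compounds shown leave open whether other groups on this carbonyl carbon, such as morpholin-4-yl with oxygen in the ring or an open-chain dimethylamino group, would also stay within the scatter of compound 3. They also leave open whether (piperidin-1-yl)carbonyl, placed where compound 2 carries (thiomorpholin-4-yl)carbonyl, would read like compound 2, which would separate the effect of the chain from that of the ring.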